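The source may hold more compounds than are shown below. What is called first, only, known or untested is meant among the compounds shown, and "the series" means these compounds.

Measured in a functional assay on Ehrlich cells (Mus musculus) for antiproliferative activity, read by trypan blue exclusion, with a stated time of 2 h; on this read-out higher numbers stand for weaker inhibition and lower numbers for stronger inhibition:
- compound 1 `Cc1ccc(C2C(C#N)=C(N)N(c3ccc(S(N)(=O)=O)cc3)C3=C2C(=O)CCC3)cc1`: 50 ug/mL
- compound 2 `N#CC1=C(N)N(c2ccc(S(N)(=O)=O)cc2)C2=C(C(=O)CCC2)C1/C=C/c1ccccc1`: > 100 ug/mL (a limit)
- compound 3 `COc1ccccc1C1C(C#N)=C(N)N(c2ccc(S(N)(=O)=O)cc2)C2=C1C(=O)CCC2`: > 100 ug/mL (a limit)

Among the measured compounds shown here, compound 1 gives the only actual number, 50 ug/mL. Compound 2 and compound 3 both stand at the limit of > 100 ug/mL in this assay, at which 2 of the 3 values shown sit, so neither can be ranked against the other.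

Compound 4 `COc1ccc(C2C(C#N)=C(N)N(c3ccc(S(N)(=O)=O)cc3)C3=C2C(=O)CCC3)cc1` keeps the core of compound 1 and carries methoxy in place of methyl on an aromatic carbon, turning 4-methylphenyl into 4-methoxyphenyl.

The closest measured change also replaces 4-methylphenyl, with 2-methoxyphenyl: an at least 2.0-fold higher number from compound 1 to compound 3 (0.30 log units; that floor lies within the scatter). The change to 2-phenylethenyl reads the same: an at least 2.0-fold higher number from compound 1 to compound 2 (0.30 log units; that floor lies within the scatter). Both are floors only, so they show that changes at this carbon can weaken inhibition but do not fix a size. Here the edit is smaller, so a modest shift towards weaker inhibition in this assay is expected.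

The expected step is a 1.4-fold higher number from compound 1 to compound 4 (0.15 log units; within the scatter). Compound 4 is estimated at 70 ug/mL, with an expected range of 35 ug/mL to 140 ug/mL.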

Compound 4, half-maximal inhibitory concentration: 25 ug/mL
Estimate against measurement, compound 4: 2.8-fold (0.45 log units) above; measured number outside the range, below it.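

In this assay, methoxy in place of methyl on the aromatic carbon gives a 2.0-fold lower number from compound 1 to compound 4 (0.30 log units; within the scatter), so this edit to the 4-methylphenyl group leaves inhibition within the scatter, and compound 1 and compound 4 cannot be told apart. Among the compounds shown here, what the earlier compounds did not show is that the group on the saturated ring carbon can differ measurably while methoxy is kept: 4-methoxyphenyl in place of 2-methoxyphenyl gives an at least 4.0-fold lower number from compound 3 to compound 4 (0.60 log units; beyond the scatter), and 4-methoxyphenyl in place of 2-phenylethenyl gives an at least 4.0-fold lower number from compound 2 to compound 4 (0.60 log units; beyond the scatter). Both steps are floors, as compound 2 and compound 3 each stand at a limit of the assay: the limit of > 100 ug/mL in this assay, at which 2 of the 4 values shown sit.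

Still open, on these data alone, is how an amine or a carboxylic acid would read in place of methoxy on that aromatic carbon. Equally open, as far as these compounds go, is whether a longer chain such as ethoxy there would stay within the scatter of compound 4.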